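A Fluorine for a Methyl on the Triazole Aryl Ring

The source may hold more compounds than are shown below. What is called first, only, known or untested is meant among the compounds shown, and "the series" means these compounds.

Of the compounds shown here, three sharing one core have been measured in a functional assay on SGC-7901 cells (Homo sapiens) for antiproliferative activity, read by MTT assay, with a stated time of 24 h; a lower number here means a stronger inhibitor, a higher number a weaker inhibitor. Compound 1 `O=c1[nH]cc(S(=O)(=O)Nc2ccccc2-c2cn(-c3cccc(Cl)c3)nn2)c(=O)[nH]1` gives 2270 nM. Among the compounds with values here, compound 2 `O=c1[nH]cc(S(=O)(=O)Nc2ccccc2-c2cn(-c3ccc(Cl)cc3)nn2)c(=O)[nH]1` gives 2700 nM; the single change between the two, a 1.2-fold higher number from compound 1 to compound 2 (0.08 log units; within the scatter), leaves them indistinguishable. Compound 3 `Cc1cccc(-n2cc(-c3cccc(NS(=O)(=O)c4c[nH]c(=O)[nH]c4=O)c3)nn2)c1` gives 9100 nM, the highest of the three numbers, and its gap to compound 2 as well as to compound 1 lies beyond the scatter, so compound 3 is the weakest inhibitor of the three.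

Compound 4 `O=c1[nH]cc(S(=O)(=O)Nc2cccc(-c3cn(-c4cccc(F)c4)nn3)c2)c(=O)[nH]1` has not yet been measured. Relative to compound 3 it carries fluoro in place of methyl on an aromatic carbon. Within the data shown here, no measured pair shows this exact exchange. Among the measured compounds shown here, the one step at hand, from compound 1 to compound 2, moves a chlorine on the ring attached to the triazole nitrogen and stays within the scatter; it indicates that a small change on that ring left the number little moved, but it does not speak to methyl against fluoro, and the two cores differ in where the triazole sits. The expected step is therefore small, a 1.1-fold lower number from compound 3 to compound 4 (0.06 log units; within the scatter), with wide uncertainty. Compound 4 is expected to give 8000 nM, within 3500 nM to 18000 nM.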

Compound 4, half-maximal inhibitory concentration: > 20000 nM
Compound 4: only a limit was reported; the forecaster's own chance of this, stated with the estimate: 5%; at least 2.5-fold (0.39 log units) between middle value and limit.
By their numbers in this assay, from the lowest: compounds 1 and 2 (each within the scatter of the next); then compound 3. At a limit, above all of these: compound 4.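

In this assay, swapping methyl for fluoro on an aromatic carbon, the change from 3-methylphenyl to 3-fluorophenyl, gives an at least 2.1-fold higher number from compound 3 to compound 4 (0.34 log units; beyond the scatter), so a single-atom exchange at this position is enough to weaken the compound beyond the usual noise. Within the data shown here, the only earlier step, a 1.2-fold higher number from compound 1 to compound 2 (0.08 log units; within the scatter), moved a chlorine on the ring attached to the triazole nitrogen in a different arrangement of the core, and it gave no sign that a small change on that ring could shift the number this clearly. For compound 4, the reported > 20000 nM is a limit of the assay and not a number, so this step gives only the smallest size the change can have: the limit of > 20000 nM in this assay, at which 1 of the 4 values shown sits.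

With a single pair from this core, the compounds shown cannot separate what the entering fluoro does from what the departing methyl does, and how much weaker compound 4 really is remains unknown. A methoxy group, an amine or a longer chain such as ethyl at this position on the core of compound 3 would show whether the methyl is a special case or one of several groups that the position tolerates.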